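The source may hold more compounds than are shown below. What is called first, only, known or untested is meant among the compounds shown, and "the series" means these compounds.

Measured so far in a functional assay on A549 cells (Homo sapiens) for antiproliferative activity, read by MTT assay, with a stated time of 48 h; a higher number here means a weaker inhibitor of growth, a lower number a stronger inhibitor of growth:

- compound 1 `CCCOC(=O)N1N=C(c2ccccc2)CC1c1cc(OC)c(OC)c(OC)c1` gives > 10000 nM, which is a limit of the assay and not a number.
- compound 2 `CCCOC(=O)N1N=C(c2cccc(O)c2)CC1c1cc(OC)c(OC)c(OC)c1` gives > 10000 nM, again a limit of the assay and not a number.
- compound 3 `COC(=O)N1N=C(c2ccccc2)CC1c1ccc(OC)c(O)c1` gives 8930 nM.

Going by the values given here, compound 3 is the only one with a number; the other two sit at the limit of > 10000 nM in this assay, at which 2 of the 3 values shown sit. The difference between the core of compound 3 and that of compound 2 is not broken down here.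

Compound 4 `COC(=O)N1N=C(c2ccccc2)CC1c1ccc(OC)cc1` is not yet measured. It differs from compound 3 by hydrogen in place of hydroxy on an aromatic carbon. The same kind of change is already seen from compound 2 to compound 1 (hydrogen in place of hydroxy on an aromatic carbon), where the step that the two limits leave unreadable from compound 2 to compound 1 could not be read because the limit of > 10000 nM in this assay, at which 2 of the 3 values shown sit, hides its size. The two places differ in their surroundings: in compound 3 the hydroxy sits ortho to a methoxy group (2 heavy atoms), whereas in compound 2 it does not.

For compound 4 in this assay a step of about a 1.7-fold higher number from compound 3 to compound 4 (0.23 log units; within the scatter) is expected, a cautious guess resting on the weak growth inhibition of compound 3 at 8930 nM. Compound 4 is therefore estimated at 15000 nM, between 5000 nM and 50000 nM.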

Compound 4, concentration for 50% growth inhibition: 15300 nM
Compound 4: the middle estimate sits 1.0-fold (0.01 log units) below what was measured, within the range that was stated.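

Putting hydrogen in place of the hydroxy on the core of compound 3 gives, in this assay, a 1.7-fold higher number from compound 3 to compound 4 (0.23 log units; within the scatter), so on this core the swap has no effect that can be told apart from ordinary variation between repeat measurements. The same swap from compound 2 to compound 1 cannot be read, because both values are limits of the assay and not numbers: the limit of > 10000 nM in this assay, at which 2 of the 4 values shown sit. Going by these compounds alone, the one readable step therefore comes from a single core, where the hydroxy sits ortho to a methoxy group, and it does not show whether the swap would behave alike on the core of compound 2.

Going by these compounds, it remains open whether another group in this place, such as an amine or a carboxylic acid, would shift the number beyond the scatter. On these data alone, it also remains open whether the result for this swap would hold on any further core.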